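A few compounds are considered here, and "the series" means these few. Any claim that something is new, unique, unknown or untested is made for them only; others in the source may bear on it.

In an ADME assay on HEK293 cells (Homo sapiens) for cytotoxicity, with a stated time of 72 h (on this read-out lower numbers stand for an effect already at smaller amounts and higher numbers for an effect only at larger amounts of compound), compound 1 `C=C[C@@](C)(/C=C/c1ccc(Nc2ccccc2)cc1)CCC=C(C)C` gives > 36600 nM as a limit and not a number. Compound 2 `C=C[C@@](C)(/C=C/c1ccc(Nc2ccc(OC)cc2)cc1)CCC=C(C)C` gives > 36600 nM, again a limit. Compound 3 `C=C[C@@](C)(/C=C/c1ccc(Nc2ccc(Cl)c(F)c2)cc1)CCC=C(C)C` gives > 36600 nM, also a limit. Compound 3 therefore has no number of its own and stands with the other two: the limit of > 36600 nM in this assay, at which 3 of the 3 values shown sit.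

The next change leads to compound 4 `C=C[C@@](C)(/C=C/c1ccc(Nc2cc(F)c(F)cc2F)cc1)CCC=C(C)C`, with 2,4,5-trifluorophenyl in place of 4-chloro-3-fluorophenyl on a nitrogen on an aromatic ring.

Two measured exchanges on that nitrogen bear on it: a step that the two limits leave unreadable from compound 1 to compound 3 and a step that the two limits leave unreadable from compound 2 to compound 3. The remaining one, methoxy in place of hydrogen on an aromatic carbon, is a step that the two limits leave unreadable from compound 1 to compound 2. None of these has a readable size, so the series offers no sign of a shift, and no step beyond the scatter is expected in this assay. The estimated step is a step that the limit leaves unreadable from compound 3 to compound 4 and has no expected direction. Another limit is the likeliest report. For compound 4 the expected value is 40000 nM, with an estimated range from 20000 nM to 80000 nM.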

Compound 4, half-maximal effective concentration: > 36600 nM
Compound 4: a limit, no number; the forecaster's own chance of this, stated with the estimate: 85%; the middle value lies beyond the limit too.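

In this assay compound 4 gives > 36600 nM, a limit and not a number, so no step from compound 1, compound 2 or compound 3 to compound 4 can be read: the limit of > 36600 nM in this assay, at which 4 of the 4 values shown sit.

Going by these compounds, whether any exchange on the nitrogen shifts the result in this assay, and in which direction, stays open.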